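Cytotoxicity notes on a shared-core series

The compounds below may be only part of what the source reports. "The series", "measured", "known", "first", "only" and "open" are said of these compounds alone.

Measured compounds:
compound 1, `CCCc1ccc(-c2ccc3ncc(C(=O)OCC)cc3c2)cc1`, in a functional assay on RD cells (Homo sapiens) for inhibition, read by luminescence and ATP content, with a stated time of 72 h; on this read-out lower numbers stand for higher toxicity in this test and higher numbers for lower toxicity in this test: > 7400 nM
compound 2, `Cc1nc(-c2cnc3ccc(-c4ccc(N)cc4)cc3c2)no1`, in this assay: > 2500 nM
compound 3, `CCCCc1ccc(-c2ccc3ncc(-c4noc(C)n4)cc3c2)cc1`, in this assay: > 2500 nM

All three values are limits of the assay, not numbers. Compound 3 stands at a limit, as does compound 2, which is the limit of > 2500 nM in this assay, at which 2 of the 3 values shown sit; compound 1 stands at a different limit, which is the limit of > 7400 nM in this assay, at which 1 of the 3 values shown sits. Among the compounds with values here, the only one-place step among the measured compounds, from compound 2 to compound 3, is a step that the two limits leave unreadable from compound 2 to compound 3, butyl in place of amino on an aromatic carbon, so no size can be read from it.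

The next compound is compound 4, `CCCc1ccc(-c2ccc3ncc(-c4noc(C)n4)cc3c2)cc1`. It differs from compound 3 by hydrogen in place of methyl on a saturated chain carbon, three bonds along the chain from an aromatic carbon; cut one bond further out this reads butyl to propyl. Within the data shown here, no measured step resolves the size of such a change, and every value shown is a limit, so no step beyond the scatter is expected in this assay. Compound 4 is therefore expected to sit again at or beyond the limit, estimated at 6000 nM within 2500 nM to 25000 nM, an expected step that the limit leaves unreadable from compound 3 to compound 4.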

Compound 4, half-maximal cytotoxic concentration: > 7400 nM
Compound 4: a limit, no number (the forecaster's own chance of this, stated with the estimate: 85%); middle value at least 1.2-fold (0.09 log units) away from the limit.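

In this assay compound 4 gives > 7400 nM, a limit and not a number, so no step can be read between it and compound 1, compound 2 or compound 3. The compounds shown leave open the concentration at which any of them becomes toxic in this assay, and with it the size of any step among them.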